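The source may hold more compounds than are shown below. What is called first, only, known or untested is meant among the compounds shown, and "the series" means these compounds.

The study assesses compound 1 `O=S(=O)(Nc1ccc2oc(-c3ccccc3)nc2c1)c1cccc(F)c1` for cytotoxicity in an ADME assay on HEK293 cells (Homo sapiens) for cytotoxicity, read by resazurin assay, with a stated time of 48 h (a higher number here means that more compound is tolerated, a lower number that less compound is tolerated), where compound 1 gives 68000 nM. Compound 2 `O=S(=O)(Nc1ccc2oc(-c3ccccc3)nc2c1)c1ccc(F)c(C(F)(F)F)c1` returns only a limit of the assay in this assay, > 100000 nM. Going by the values given here, compound 1 thus holds the only numerical value so far, the other result being a limit (the limit of > 100000 nM in this assay, at which 1 of the 2 values shown sits). The next compound, compound 3 `COc1ccccc1S(=O)(=O)Nc1ccc2oc(-c3ccccc3)nc2c1`, differs from compound 1 in one place: 2-methoxyphenyl in place of 3-fluorophenyl on a sulfonyl sulfur. Among the compounds with values here, no step between two measured compounds is available to guide the size of this change, so the expected step in this assay from compound 1 to compound 3 is judged small, likely within the usual scatter, with a slight lean toward more compound being tolerated. On that basis compound 3 is expected to show 80000 nM, with a range from 35000 nM to 150000 nM. The step this estimate implies is a 1.2-fold higher number from compound 1 to compound 3 (0.07 log units; within the scatter).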

Compound 3, half-maximal cytotoxic concentration: 41000 nM
The estimate for compound 3 lay 2.0-fold (0.29 log units) above the measured number; the measured number falls inside the stated range.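

Going by these compounds alone, compound 3 gives the first step that can be read in this assay, at the sulfonyl sulfur: a 1.7-fold lower number from compound 1 to compound 3 (0.22 log units; within the scatter). The step lies within the scatter, so at this place 2-methoxyphenyl and 3-fluorophenyl cannot be told apart in this read-out, although the entering group carries a hydrogen-bond acceptor that the leaving group does not. Nothing shown bears on why compound 3 gives the number it does.

Within the data shown here, compound 2 gives only a limit of the assay, and no step to it can be read: the limit of > 100000 nM in this assay, at which 1 of the 3 values shown sits. From the compounds shown here alone, it remains open whether a group of another kind on the sulfonyl sulfur, such as an amine or a carboxylic acid in place of 3-fluorophenyl, would give a step beyond the scatter.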